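The source may hold more compounds than are shown below. What is called first, only, known or untested is meant among the compounds shown, and "the series" means these compounds.

Measured in a functional assay on HT-29 cells (Homo sapiens) for antiproliferative activity, read by sulforhodamine B assay, with a stated time of 48 h; on this read-out lower numbers stand for stronger inhibition and higher numbers for weaker inhibition:
- compound 1 `CCc1ccccc1OS(=O)(=O)c1ccc(N2CCN(C)C2=O)cc1`: 4600 nM
- compound 2 `CCN1CCN(c2ccc(S(=O)(=O)Oc3cccc(I)c3)cc2)C1=O`: 3100 nM
- compound 3 `CCCN1CCN(c2ccc(S(=O)(=O)Oc3ccccc3CC)cc2)C1=O`: > 100000 nM (a limit)

Compound 3 has only a limit and no number, > 100000 nM. Compound 4 `CCCN1CCN(c2ccc(S(=O)(=O)Oc3c(Cl)cc(Cl)cc3Cl)cc2)C1=O` differs from compound 3 at one place: 2,4,6-trichlorophenyl in place of 2-ethylphenyl on an oxygen. Going by the values given here, no measured step covers a change at that oxygen. Among the compounds with values here, the one measured step lies elsewhere, an at least 21-fold higher number from compound 1 to compound 3 (1.33 log units; beyond the scatter), and compound 4 retains the chain that compound 3 gained in it. From that step, weak inhibition is expected to persist in this assay, with a move toward lower numbers possible but uncertain in size. The expected change is an at least 4.0-fold lower number from compound 3 to compound 4 (0.60 log units; beyond the scatter). For compound 4 the estimate is 25000 nM, expected to lie between 3000 nM and 100000 nM.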

Compound 4, half-maximal inhibitory concentration: 56000 nM
Beside the measured number, compound 4's estimate is 2.2-fold (0.35 log units) below it; the measured number falls inside the stated range.
By their numbers in this assay, from the lowest: compounds 2 and 1 (each within the scatter of the next); then compound 4. At a limit, above all of these: compound 3.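

Changing the group on the oxygen bound to the sulfonyl sulfur, with the propyl chain kept, gives compound 4 a measured value in this assay, 56000 nM. Compound 3 has only a limit, > 100000 nM. The step is an at least 1.7-fold lower number from compound 3 to compound 4 (0.25 log units; that floor lies within the scatter), so 2,4,6-trichlorophenyl in place of 2-ethylphenyl is not shown to act beyond the scatter, and its true size stays unread: the limit of > 100000 nM in this assay, at which 1 of the 4 values shown sits.

Open, from the compounds shown here alone, is how 2,4,6-trichlorophenyl reads with the shorter chain of compound 1, and how an amine or a carboxylic acid on the aromatic ring at this oxygen would read.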